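The compounds below may be only part of what the source reports. "The series", "measured", "known", "first", "only" and "open" are said of these compounds alone.

Measured so far:
- compound 1 `Fc1ccc(-c2cn3ccnc3c(-c3ccc4ncn(C5CCCCC5)c4c3)n2)cc1`: 2.03%
- compound 2 `Fc1ccccc1-c1cn2ccnc2c(-c2ccc3ncn(C4CCCCC4)c3c2)n1`: 9.3%

Both numbers come from a functional assay on HL-60 cells (Homo sapiens) for inhibition, read by sulforhodamine B assay, with a stated time of 48 h, tested at 10 uM; on this read-out higher numbers stand for more inhibition at the one concentration tested (going by the name of the read-out) and lower numbers for less inhibition. In this assay compound 1 gives 2.03% and compound 2 gives 9.3%. The single measured step, a number 7.3 percentage points higher from compound 1 to compound 2 (within the scatter), is within the scatter, so compound 2 and compound 1 are not separated by the numbers shown; both sit at weak inhibition.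

Compound 3 `c1csc(-c2cn3ccnc3c(-c3ccc4ncn(C5CCCCC5)c4c3)n2)c1` is not yet measured. It differs from compound 2 by thiophen-2-yl in place of 2-fluorophenyl on an aromatic carbon. Among the compounds with values here, no measured step involves a thiophen-2-yl group or the exchange of a six-membered ring for a five-membered one, so the only guide is the flat behaviour of the series across the fluorophenyl change. On that basis compound 3 is expected to stay near compound 2, with a step of a number 0.3 percentage points lower from compound 2 to compound 3 (within the scatter), not beyond the scatter. The estimated value for compound 3 in this assay is 9%, within a range from -10% to 30%.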

Compound 3, a percentage reported as inhibition, at one concentration (the size of the read-out at that concentration, not a potency): 26.6%
Compound 3: middle estimate off by 17.6 percentage points, on the low side; low and high end bracket the measured number.
By their numbers in this assay, from the lowest: compounds 1 and 2 (each within the scatter of the next); then compound 3.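

Going by this assay and its steps, the aromatic carbon carrying these rings is not as flat as the two fluorophenyl compounds suggested: thiophen-2-yl in place of 2-fluorophenyl gives a number 17.3 percentage points higher from compound 2 to compound 3 (beyond the scatter) and thiophen-2-yl in place of 4-fluorophenyl gives a number 24.6 percentage points higher from compound 1 to compound 3 (beyond the scatter) while those two compounds remain within the scatter of each other. The ring at this carbon can therefore shift inhibition at the one concentration tested, and compound 3 gives 26.6%. Nothing on hand separates the roles of ring size, the ring sulfur and the missing fluorine in this step.

From the compounds shown here alone, whether the gain belongs to thiophen-2-yl alone or extends to other five-membered aromatic rings, such as furan-2-yl, remains open. Also open, going by these compounds, is what an amine or a carboxylic acid on this ring would do, and a single concentration leaves potency unanswered.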